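This account rests on a few compounds, and the source may have more. Where it says the series, first, only, none or still open, it means among the compounds named here.

Measured so far in an ADME assay on Huh-7 cells (Homo sapiens) for cytotoxicity, with a stated time of 72 h; on this read-out lower numbers stand for higher toxicity in this test and higher numbers for lower toxicity in this test:
compound 1 `CC(C)CCn1nc(C2CCC2)c(O)c(C2=NS(=O)(=O)c3cc(NS(C)(=O)=O)ccc3N2)c1=O` — > 33000 nM
compound 2 `CC(C)=Cc1nn(CCC(C)C)c(=O)c(C2=NS(=O)(=O)c3cc(NS(C)(=O)=O)ccc3N2)c1O` — > 1000 nM
compound 3 `COC(C)(C)CCn1nc(-c2cccs2)c(O)c(C2=NS(=O)(=O)c3cc(NS(C)(=O)=O)ccc3N2)c1=O` — > 33000 nM

Each of these three values is a limit of the assay and not a number. Compound 3 sits at the limit described by the limit of > 33000 nM in this assay, at which 2 of the 3 values shown sit, where two of the three values rest. Compound 2 stands at the other limit, (the limit of > 1000 nM in this assay, at which 1 of the 3 values shown sits). Among the compounds with values here, the one exchange that can be compared, a step that the two limits leave unreadable from compound 1 to compound 2, is left unreadable by the two limits, so no measured step has a size in this assay.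

The next compound, compound 4 `CS(=O)(=O)Nc1ccc2c(c1)S(=O)(=O)N=C(c1c(O)c(-c3cccs3)nn(Cc3ccccn3)c1=O)N2`, differs from compound 3 by pyridin-2-yl in place of 2-methoxy-2-methylpropyl on a saturated chain carbon bound to an aromatic nitrogen. Within the data shown here, no measured step bears on this exchange; none of the three compounds tests a substituent of this kind on a saturated chain carbon bound to an aromatic nitrogen, and all three measured values lie at limits without a numeric read-out to draw on. The expectation is therefore that compound 4 will again sit at or near the limit, with a step that the limit leaves unreadable from compound 3 to compound 4 expected to be no step beyond the scatter in this assay. Compound 4 is estimated at 40000 nM, with a range from 8000 nM to 150000 nM, most likely reported only as a limit.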

Compound 4, half-maximal cytotoxic concentration: > 1000 nM
Compound 4 was reported as a limit; the forecaster's own chance of this, stated with the estimate: 75%; the middle value lies beyond the limit too.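

In this assay compound 4 gives > 1000 nM, a limit and not a number. Compound 3 gives > 33000 nM, also a limit, so no step can be read between compound 3 and compound 4. The compounds shown leave open whether pyridin-2-yl in place of 2-methoxy-2-methylpropyl changes the half-maximal cytotoxic concentration at all.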